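The source may report more compounds than this note shows. Statements on the series, on what has been measured and on what is new or still open speak of the compounds shown alone.

Of the compounds shown here, three have been measured in a functional assay on PANC-1 cells (Homo sapiens) for antiproliferative activity, read by fluorescence and resazurin assay, with a stated time of 48 h; a higher number here means a weaker inhibitor, a lower number a stronger inhibitor. Compound 1 `CCOc1ccc2nc(Cl)c(/C=N/NC(=O)c3cc4cc([N+](=O)[O-])ccc4oc3=O)cc2c1` gives 10500 nM in this assay. Compound 2 `CCOc1ccc2nc(Cl)c(/C=N/NC(=O)c3cc4ccccc4oc3=O)cc2c1` gives 29900 nM. Compound 3 `Cc1noc(NS(=O)(=O)c2ccc(NC(=O)c3cc4ccccc4oc3=O)cc2)c1C`, which is built on a different core, gives 19900 nM; the difference between its core and that of compound 2 is not broken down here, and the two values lie within the scatter of each other, so no order between them can be claimed.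

Compound 1 and compound 2 differ in one place, (nitro in place of hydrogen on an aromatic carbon), and the step is a 2.8-fold lower number from compound 2 to compound 1 (0.45 log units; beyond the scatter). Compound 4 `Cc1noc(NS(=O)(=O)c2ccc(NC(=O)c3cc4cc([N+](=O)[O-])ccc4oc3=O)cc2)c1C` has not been measured yet; it differs from compound 3 in exactly the same way, (nitro in place of hydrogen on an aromatic carbon), and the place of the change is described in the same terms for both pairs, so it counts as the same change.

Among the measured compounds shown here, the step from compound 3 to compound 4 is therefore expected to resemble the one from compound 2 to compound 1, because the step of a 2.8-fold lower number from compound 2 to compound 1 (0.45 log units; beyond the scatter) is the only precedent for this change, although it rests on a single pair and on a different core. Compound 4 is expected to show a step of a 2.5-fold lower number from compound 3 to compound 4 (0.40 log units; beyond the scatter). Compound 4 is estimated at 8000 nM in this assay. Compound 4 is expected to fall between 3500 nM and 18000 nM.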

Compound 4, half-maximal inhibitory concentration: 11900 nM
Beside the measured number, compound 4's estimate is 1.5-fold (0.17 log units) below it, within the range that was stated.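

Placed on the core of compound 3, nitro in place of hydrogen on an aromatic carbon gives, in this assay, a 1.7-fold lower number from compound 3 to compound 4 (0.22 log units; within the scatter), so on this core the effect of the change alone cannot be told apart from the scatter of repeated measurements. Among the compounds shown here, this result is compatible with the change carrying over from one core to the other, but it does not establish a transfer, since only two pairs bear on the question and only one of their steps lies beyond the scatter. Nor does it show that the change acts in the same way on both cores, or that the step has the same true size on each, and the comparison supports only a limited statement, that the two steps cannot be separated: the same change on two cores in this assay, a 2.8-fold lower number (0.45 log units; beyond the scatter) from compound 2 to compound 1 and a 1.7-fold lower number (0.22 log units; within the scatter) from compound 3 to compound 4, 1.7-fold (0.23 log units) apart, within the scatter of two such steps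

The compounds shown leave open whether an amine, a nitrile or a methoxy group on the same aromatic carbon would give a step of similar size on either core. They also leave open whether the nitro step would hold on a third core, where a further pair could help to show whether the step on the core of compound 1 or the one on the core of compound 3 is the more typical.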